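Aryl swaps on the amine of a shared core

The compounds below may be only part of what the source reports. "The series", "measured", "known", "first", "only" and "open" are said of these compounds alone.

Compound 1 `Cc1ccc(NC2=CC(=O)c3nc4n(c3C2=O)[C@H]2OC[C@@H](O)[C@H]2OC4)cc1`: 3860 nM
Compound 2 `CCCc1ccc(NC2=CC(=O)c3c(nc4n3[C@H]3OC[C@@H](O)[C@H]3OC4)C2=O)cc1`: 6030 nM
Compound 3 `O=C1C=C(Nc2cccc(Cl)c2)C(=O)c2c1nc1n2[C@H]2OC[C@@H](O)[C@H]2OC1`: 6040 nM

These three compounds share one core and differ only in the aryl group on the amine nitrogen. In a functional assay on HeLa cells (Homo sapiens) for inhibition, read by sulforhodamine B assay (a lower number here means a stronger inhibitor, a higher number a weaker inhibitor), compound 2 gives 6030 nM, a number within the usual scatter of compound 3 with 6040 nM and of compound 1 with 3860 nM. Compound 4 `O=C1C(Nc2ccccc2F)=CC(=O)c2c1nc1n2[C@H]2OC[C@@H](O)[C@H]2OC1` is not yet measured; it differs from compound 2 as follows: 2-fluorophenyl in place of 4-propylphenyl on an amine nitrogen. Within the data shown here, the one measured step that bears on this, a change of the aryl group on the same amine nitrogen, is a 1.6-fold higher number from compound 1 to compound 3 (0.19 log units; within the scatter), which stayed within the scatter. On that basis no step beyond the scatter is expected, so a 1.2-fold lower number from compound 2 to compound 4 (0.08 log units; within the scatter) is the estimated outcome. Compound 4 is therefore expected near 5000 nM, between 2000 nM and 13000 nM.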

Compound 4, half-maximal inhibitory concentration: 9820 nM
Beside the measured number, compound 4's estimate is 2.0-fold (0.29 log units) below it; measured number inside the range.
By their numbers in this assay, from the lowest: compounds 1, 2, 3 and 4 (each within the scatter of the next, the first and the last beyond it).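

Exchanging 4-propylphenyl for 2-fluorophenyl on the amine nitrogen gives a 1.6-fold higher number from compound 2 to compound 4 (0.21 log units; within the scatter) in this assay. This is a second aryl change at this position that stays within the scatter, now with a fluorine on the ring, so the four aryl groups shown do not separate step by step, although compounds 1 and 4 do lie beyond the scatter of each other. Nothing available accounts for this step. Still open, going by these compounds, is whether a phenyl ring bearing a carboxylic acid or an amine, or a cyclohexyl group on this nitrogen, would move the number beyond the scatter.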